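A Second Methyl on the Pyridine of Compound 2

This account rests on a few compounds, and the source may have more. Where it says the series, first, only, none or still open, it means among the compounds named here.

In an ADME assay for permeability, using PAMPA, with a stated time of 4 h (on this read-out higher numbers stand for higher permeability and lower numbers for lower permeability), compound 1 `Cn1c(COc2cccc(C(=O)O)c2)nc2ccc(Oc3cccc(Cl)n3)cc21` gives 7.6 10^-6 cm/s and compound 2 `Cc1ccc(Oc2ccc3nc(COc4cccc(C(=O)O)c4)n(C)c3c2)nc1` gives 4.8 10^-6 cm/s. Among the measured compounds shown here, these are the only two measurements so far, and they lie within the scatter of each other, so compound 2 cannot be separated from its sole neighbour. Compound 3 `Cc1ccc(C)c(Oc2ccc3nc(COc4cccc(C(=O)O)c4)n(C)c3c2)n1` carries 3,6-dimethylpyridin-2-yl in place of 5-methylpyridin-2-yl on an oxygen on an aromatic ring. For the measured compounds named here, only one measured step bears on this change: a 1.6-fold lower number from compound 1 to compound 2 (0.20 log units; within the scatter). It exchanged 6-chloropyridin-2-yl for 5-methylpyridin-2-yl at the same place and stayed within the scatter. Going by the values given here, no measured compound carries 3,6-dimethylpyridin-2-yl, so that single step is a thin guide, and no shift beyond the scatter is foreseen in either direction. The expected change is a 1.1-fold higher number from compound 2 to compound 3 (0.06 log units; within the scatter). In this assay, compound 3 is estimated at 5.5 10^-6 cm/s, with an expected range of 2.5 10^-6 cm/s to 12 10^-6 cm/s.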

Compound 3, apparent permeability: 11 10^-6 cm/s
Compound 3: middle estimate off by 2.0-fold (0.30 log units), on the low side; the measured number falls inside the stated range.
By their numbers in this assay, from the lowest: compounds 2, 1 and 3 (each within the scatter of the next, the first and the last beyond it).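

In this assay, among the compounds shown here, 3,6-dimethylpyridin-2-yl in place of 5-methylpyridin-2-yl on an oxygen on an aromatic ring gives a 2.3-fold higher number from compound 2 to compound 3 (0.36 log units; beyond the scatter), the first step at this place to lie beyond the scatter, so the group on this oxygen can move the number measurably. Replacing 6-chloropyridin-2-yl with the same group gives a 1.4-fold higher number from compound 1 to compound 3 (0.16 log units; within the scatter), so compound 3 stands clear of compound 2 but not of compound 1. No measured evidence accounts for the step from compound 2 to compound 3.

The compounds shown leave open whether both methyl groups of 3,6-dimethylpyridin-2-yl are needed for this step, since the change also removes the methyl group of 5-methylpyridin-2-yl. They also leave open how a plain phenyl ring or a chain ending in an amine would read on the same oxygen.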